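The source may report more compounds than this note shows. Statements on the series, on what has been measured and on what is new or still open speak of the compounds shown alone.

Measured compounds:
compound 1 `CC1=C(C(=O)NC(C)C)C(c2ccco2)NC(=O)N1`: 2%
compound 2 `CCN(CC)C(=O)C1=C(C)NC(=O)NC1c1ccco1`: 31%
compound 3 `CC1=C(C(=O)NC(C)C)C(c2ccsc2)NC(=O)N1`: 3%

All three were tested in an assay on membranes from HEK293 cells for displacement of a labelled ligand from adenosine receptor A2b (Homo sapiens), read by scintillation counting, with a stated time of 30 min, tested at 1 uM; on this read-out lower numbers stand for less inhibition and higher numbers for more inhibition at the one concentration tested (going by the name of the read-out). Compound 2 is the only one of the three that shows clear displacement in this assay; compound 1 and compound 3 lie close to each other, their values being within the scatter of each other, so no order between them can be read.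

Two single-point changes connect the measured compounds. The first, from compound 1 to compound 2, is diethylamino in place of isopropylamino on a carbonyl carbon and carries the step of a number 29 percentage points higher from compound 1 to compound 2 (beyond the scatter), a modest rise that lies beyond the scatter. The second, from compound 1 to compound 3, is thiophen-3-yl in place of furan-2-yl on a saturated ring carbon and gives a number 1 percentage points higher from compound 1 to compound 3 (within the scatter), which is within the scatter and so counts as no change.

Compound 4 `CCN(CC)C(=O)C1=C(C)NC(=O)NC1c1ccsc1` has not yet been measured in this assay. Within the data shown here, its difference from compound 3 is diethylamino in place of isopropylamino on a carbonyl carbon; this is the same change as the one made from compound 1 to compound 2, at a place that is described in the same words, but now on the core of compound 3 rather than the core of compound 1. The expectation rests on that one earlier step: because a number 29 percentage points higher from compound 1 to compound 2 (beyond the scatter) was the only effect seen for this change, a step of similar size is expected here, namely a number 27 percentage points higher from compound 3 to compound 4 (beyond the scatter), with the usual scatter making the repeat uncertain. For compound 4 the value in this assay is therefore estimated at 30%, expected to fall between 10% and 50%.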

Compound 4, a percentage reported as inhibition, at one concentration (the size of the read-out at that concentration, not a potency): 11%
For compound 4 the middle estimate is 19 percentage points above the measured one, and the stated range covers the measured number.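

On the core of compound 3, diethylamino in place of isopropylamino gives a number 8 percentage points higher from compound 3 to compound 4 (within the scatter), so the rise seen on the core of compound 1 in this assay does not carry over at its earlier size: the same change on two cores in this assay, a number 29 percentage points higher (beyond the scatter) from compound 1 to compound 2 and a number 8 percentage points higher (within the scatter) from compound 3 to compound 4, 21 percentage points apart, beyond the scatter of two such steps

Read from the other place, thiophen-3-yl in place of furan-2-yl on a saturated ring carbon gives a number 20 percentage points lower from compound 2 to compound 4 (beyond the scatter), although the same change made no readable difference on the core of compound 1: the same change on two cores in this assay, a number 1 percentage points higher (within the scatter) from compound 1 to compound 3 and a number 20 percentage points lower (beyond the scatter) from compound 2 to compound 4, 21 percentage points apart, beyond the scatter of two such steps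

Across these four compounds, the effect of each change therefore depends on the group at the other place, but this rests on a single pair of steps per change and does not show why the steps differ, nor whether the same holds for other groups in the series.

The compounds shown leave open whether a cyclic amine such as piperidine on the carbonyl carbon, or a phenyl group on the saturated ring carbon, would follow compound 2 or compound 4. Also open, on these data alone, is how these differences at a single concentration relate to potency, since the read-out gives the size of the inhibition at that concentration only.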